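The source may report more compounds than this note shows. Statements on the series, on what has been measured and on what is new or still open speak of the compounds shown alone.

Measured compounds:
Compound 1, `C/C(=C\c1cc(-c2ccccc2)cs1)C(N)=O`. In a functional assay on A549 cells (Homo sapiens) for cytotoxicity, read by CCK-8 assay, with a stated time of 24 h (on this read-out higher numbers stand for weaker inhibition and lower numbers for stronger inhibition), compound 1 gives > 50000 nM, which is a limit of the assay and not a number.
Compound 2, `C/C(=C\c1cc(-c2ccc(F)cc2)cs1)C(N)=O`. In this assay compound 2 gives > 50000 nM, likewise a limit.

Compound 2 thus stands at the limit, a position shared as the limit of > 50000 nM in this assay, at which 2 of the 2 values shown sit. Among the measured compounds shown here, the single measured step, a step that the two limits leave unreadable from compound 1 to compound 2, cannot be read in size, since both of its ends are limits. The next compound, compound 3 `C/C(=C\c1cc(-c2ccc(C#N)cc2)cs1)C(N)=O`, differs from compound 2 by cyano in place of fluoro on an aromatic carbon. For the measured compounds named here, no measured step bears directly on this change, and the one step measured, a fluoro in place of hydrogen, gives no readable size. On the numbers shown there is no ground to expect compound 3 to move off the limit in this assay. The step that the limit leaves unreadable from compound 2 to compound 3 is expected to be none beyond the scatter. Compound 3 is therefore estimated at 100000 nM, within 30000 nM to 400000 nM, and most likely reported again only as a limit.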

Compound 3, half-maximal inhibitory concentration: > 50000 nM
Compound 3 was reported as a limit (the forecaster's own chance of this, stated with the estimate: 85%); the middle value lies beyond the limit too.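

In this assay compound 3 gives > 50000 nM, again a limit and not a number. None of the steps among compound 1, compound 2 and compound 3 can be read in size. The compounds shown leave open at what concentration any of them would inhibit these cells, and whether fluoro or cyano changes that concentration.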